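Thiazolylmethoxy series: aryl swap on the thiazole

A few compounds are considered here, and "the series" means these few. Any claim that something is new, unique, unknown or untested is made for them only; others in the source may bear on it.

Two members of this series have numbers in a functional assay on CHO cells for agonist activity at Free fatty acid receptor 1 (Homo sapiens), read by FLIPR and calcium flux, tested at 100 nM; on this read-out lower numbers stand for a weaker effect and higher numbers for a stronger effect at the one concentration tested. Compound 1 `O=C(O)CC1COc2cc(OCc3cc(-c4ccccc4)on3)ccc21` gives 0.84% in this assay. Compound 2 `Cc1nc(-c2cccc3ccccc23)sc1COc1ccc2c(c1)OCC2CC(=O)O` gives 8.53% in this assay, the higher of the two numbers, though the gap to compound 1 lies within the scatter, so no order between them can be stated. Both sit at the low end of the read-out scale.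

Compound 3 `Cc1nc(-c2ccc(F)cc2)sc1COc1ccc2c(c1)OCC2CC(=O)O` is the next member. It keeps the core of compound 2 and changes one place: 4-fluorophenyl in place of naphthalen-1-yl on an aromatic carbon. For the measured compounds named here, nothing measured so far tests what an aryl swap at this position does, since compound 1 and compound 2 differ in more than one place and no single-point step is on hand.

Going by the values given here, with no comparable step to lean on and both measured numbers low, compound 3 is expected to stay in the same low region, with a number 3.5 percentage points lower from compound 2 to compound 3 (within the scatter) as the expected step, not beyond the scatter in either direction. The estimate for compound 3 in this assay is 5%, with a range from 0% to 20%.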

Compound 3, a percentage reported as activity, at one concentration (the size of the read-out at that concentration, not a potency): 61.6%
Compound 3: middle estimate off by 56.6 percentage points, on the low side; the whole stated range lies below it.
By their numbers in this assay, from the lowest: compounds 1 and 2 (each within the scatter of the next); then compound 3.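

For the compounds shown here, the first single-point step shows that the aryl group on this carbon of the five-membered aromatic ring with 1 nitrogen and 1 sulfur has a strong bearing on the read-out in this assay, with 4-fluorophenyl in place of naphthalen-1-yl giving a number 53.1 percentage points higher from compound 2 to compound 3 (beyond the scatter) and the rest of the structure unchanged. The swap replaces two six-membered aromatic rings of carbon only with one such ring bearing a fluorine, so this single pair cannot separate the loss of the second ring from the entry of the fluorine. Nothing on hand gives a reason for the size of this step.

The compounds shown leave open whether the fluorine is needed at all, a question that plain phenyl or 4-chlorophenyl on the same carbon would bear on directly. Also open, going by these compounds, is whether the step carries over to potency, since this read-out gives the size of the effect at one concentration only, and whether the methyl group on the same ring can be replaced by ethyl or hydrogen.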